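Indanyl amine hydroxylation on a sulfamate triazolopyrimidine

A few compounds are considered here, and "the series" means these few. Any claim that something is new, unique, unknown or untested is made for them only; others in the source may bear on it.

Measured compounds:
compound 1 `NS(=O)(=O)OC[C@@H]1C[C@@H](n2nnc3c(N[C@H]4CCc5ccccc54)ncnc32)C[C@@H]1O`, 0.21 nM
compound 2 `NS(=O)(=O)OC[C@@H]1C[C@@H](n2nnc3c(NCCCc4ccccc4)ncnc32)C[C@@H]1O`, 149 nM
compound 3 `CCCCCCNc1ncnc2c1nnn2[C@@H]1C[C@@H](COS(N)(=O)=O)[C@@H](O)C1`, 21.1 nM

In an assay on a protein complex for inhibition of NEDD8 activating enzyme (Homo sapiens), read by HTRF, with a stated time of 2 h, in the presence of a further agent that is not named here (a higher number here means a weaker inhibitor, a lower number a stronger inhibitor), compound 1 stands lowest of the three numbers. The two compounds that replace its 2,3-dihydro-1H-inden-1-yl group both lose much: a 710-fold higher number from compound 1 to compound 2 (2.85 log units; beyond the scatter) and a 100-fold higher number from compound 1 to compound 3 (2.00 log units; beyond the scatter), both large and well beyond the scatter. Between those two, a 7.1-fold lower number from compound 2 to compound 3 (0.85 log units; beyond the scatter) is modest.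

Compound 4 `NS(=O)(=O)OC[C@@H]1C[C@@H](n2nnc3c(N[C@@H]4c5ccccc5C[C@@H]4O)ncnc32)C[C@@H]1O` keeps the indanyl amine of compound 1 and differs only in that (hydroxy in place of hydrogen on a saturated ring carbon); the place is a saturated ring carbon of the five-membered non-aromatic ring, next to the ring atom that bears a large group. Going by the values given here, no measured step touches that ring carbon; the measured steps concern removal of the whole bicyclic group, which is a far larger change than adding a hydroxy to it. The step of a 1.9-fold higher number from compound 1 to compound 4 (0.28 log units; within the scatter) is therefore expected to be small, most likely a slight rise within or near the scatter. Compound 4 is estimated at 0.4 nM, with a range from 0.1 nM to 2 nM in this assay.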

Compound 4, half-maximal inhibitory concentration: 2.28 nM
Beside the measured number, compound 4's estimate is 5.7-fold (0.76 log units) below it; measured number outside the range, above it.
By their numbers in this assay, from the lowest: compound 1; then compound 4; then compound 3; then compound 2.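

In this assay, going by these compounds alone, the saturated ring carbon of the five-membered non-aromatic ring proves sensitive: hydroxy in place of hydrogen gives an 11-fold higher number from compound 1 to compound 4 (1.04 log units; beyond the scatter), a large step from a single added oxygen, whereas the earlier compounds showed steps of this size only on replacing the whole 2,3-dihydro-1H-inden-1-yl group. The hydroxylated group still retains an advantage over the two chains, with a 9.3-fold lower number from compound 3 to compound 4 (0.97 log units; beyond the scatter) and a 65-fold lower number from compound 2 to compound 4 (1.82 log units; beyond the scatter). Nothing measured here gives a reason for the size of the step from hydrogen to hydroxy.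

On these data alone, whether the loss follows the hydroxy in its present orientation or would also appear with the opposite stereoisomer remains open. So does how a methoxy, a fluorine or an amine on the same ring carbon would compare.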